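Aryl swap on the five-membered ring nitrogen: compound 3

A few compounds are considered here, and "the series" means these few. Any claim that something is new, unique, unknown or untested is made for them only; others in the source may bear on it.

Compound 1 `Cc1ccccc1-n1nncc1CN1C(=O)C2(C(C#N)=C(N)Oc3c(N)cc4nc5ccccc5nc4c32)c2ccccc21` and compound 2 `Cc1cccc(-n2nncc2CN2C(=O)C3(C(C#N)=C(N)Oc4c(N)cc5nc6ccccc6nc5c43)c3ccccc32)c1` share one core and differ only in the aryl group on the five-membered aromatic ring with 3 nitrogen. In a functional assay on HCT-116 cells (Homo sapiens) for antiproliferative activity, read by MTT assay, with a stated time of 48 h (on this read-out lower numbers stand for stronger inhibition and higher numbers for weaker inhibition), compound 1 returns no number, only the limit > 50000 nM. In this assay compound 2 likewise gives only the limit > 50000 nM. The step that the two limits leave unreadable from compound 1 to compound 2 has no readable size; the limit of > 50000 nM in this assay, at which 2 of the 2 values shown sit, marks where both values sit. Compound 3 `CCc1ccccc1-n1nncc1CN1C(=O)C2(C(C#N)=C(N)Oc3c(N)cc4nc5ccccc5nc4c32)c2ccccc21` carries the next change: 2-ethylphenyl in place of 3-methylphenyl on an aromatic nitrogen. For the measured compounds named here, the only measured step that bears on it is a step that the two limits leave unreadable from compound 1 to compound 2, which gives no size, so no shift beyond the scatter is expected in this assay, and a limit is the likeliest outcome again. The step of a number no higher from compound 2 to compound 3 (the limit leaves the size open) is what is expected. Compound 3 is expected to give about 50000 nM, within 20000 nM to 150000 nM, in this assay.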

Compound 3, half-maximal inhibitory concentration: 10300 nM
Compound 3: middle estimate off by 4.9-fold (0.69 log units), on the high side, outside the stated range (below it).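

In this assay, the aryl group on the ring nitrogen now yields a readable number, which neither methylphenyl compound gave. Replacing 3-methylphenyl with 2-ethylphenyl gives an at least 4.8-fold lower number from compound 2 to compound 3 (0.68 log units; beyond the scatter), while adding one carbon to the chain of the 2-methylphenyl group gives an at least 4.8-fold lower number from compound 1 to compound 3 (0.68 log units; beyond the scatter), so an ethyl group at this place is enough to move the series off the limit. The step between compound 1 and compound 2 cannot be read, and both sizes above rest on limits rather than numbers: the limit of > 50000 nM in this assay, at which 2 of the 3 values shown sit.

Still open, as far as these compounds go, is whether a longer chain, such as propyl, on the same aryl ring would lower the number further. Also open, from the compounds shown here alone, is whether an amine or a carboxylic acid in place of the ethyl group would keep any of this gain.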